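Swapping the anilino arm of a covalent pyrimidine series

The source may hold more compounds than are shown below. What is called first, only, known or untested is meant among the compounds shown, and "the series" means these compounds.

Measured so far:
compound 1 `C=CC(=O)Nc1cc(Nc2ncc(Cl)c(Nc3ccccc3S(=O)(=O)C(C)C)n2)c(OC)cc1N1CCCCC1` — 29 nM
compound 2 `C=CC(=O)Nc1cc(Nc2ncc(Cl)c(Nc3ccccc3S(=O)(=O)C(C)C)n2)c(OC(C)C)cc1N1CCN(CC)CC1` — < 0.3 nM
compound 3 `C=CC(=O)Nc1cc(Nc2ncc(Cl)c(Nc3ccc(F)c(Cl)c3)n2)c(OC)cc1N1CCN(C)CC1` — 300 nM

In a functional assay on NCI-H3122 cells (Homo sapiens) for inhibition, read by CellTiter-Glo, with a stated time of 72 h (a lower number here means a stronger inhibitor of growth, a higher number a weaker inhibitor of growth), compound 1 gives 29 nM. Compound 2 reaches only < 0.3 nM, which is a limit of the assay and not a number (the limit of < 0.3 nM in this assay, at which 1 of the 3 values shown sits). Compound 3 gives 300 nM, the higher of the two numbers, and its gap to compound 1 lies beyond the scatter. Compound 4 `C=CC(=O)Nc1cc(Nc2ncc(Cl)c(N(C)c3cccc(C(F)(F)F)c3)n2)c(OC)cc1N1CCN(C)CC1` differs from compound 3 by methyl(3-(trifluoromethyl)phenyl)amino in place of (3-chloro-4-fluorophenyl)amino on an aromatic carbon. Among the compounds with values here, no measured pair shows this change, so its size is unknown. Compound 4 is expected to stand a little higher than compound 3, with the step of a 2.0-fold higher number from compound 3 to compound 4 (0.30 log units; within the scatter) estimated as modest and possibly within the scatter. The estimate for compound 4 is 600 nM, in the range 100 nM to 4000 nM.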

Compound 4, concentration for 50% growth inhibition: 3600 nM
Compound 4: middle estimate off by 6.0-fold (0.78 log units), on the low side, within the range that was stated.
By their numbers in this assay, from the lowest: compound 1; then compound 3; then compound 4. At a limit, below all of these: compound 2.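

In this assay, this position proves sensitive to the arm it carries: methyl(3-(trifluoromethyl)phenyl)amino in place of (3-chloro-4-fluorophenyl)amino gives a 12-fold higher number from compound 3 to compound 4 (1.08 log units; beyond the scatter). The change takes away the arm's hydrogen-bond donor and alters the ring's substituents in a single step, so the two changes cannot be told apart. Nothing measured here accounts for the size of this step. Open, on these data alone, is how a (3-(trifluoromethyl)phenyl)amino arm that keeps its amine hydrogen would stand, and how an ethyl in place of the methyl on that nitrogen would.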